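Styryl-to-biaryl swap with an entering dimethylamino group

The source may hold more compounds than are shown below. What is called first, only, known or untested is meant among the compounds shown, and "the series" means these compounds.

Measured compounds:
- compound 1, `COC(=O)/C=C/c1cccc(N(Cc2ccc(/C=C/c3cccc(C(F)(F)F)c3)cc2)C(=O)C(C)C)c1`: in an assay on isolated protein with Bile acid receptor (Homo sapiens) as the target (on this read-out higher numbers stand for an effect only at larger amounts of compound and lower numbers for an effect already at smaller amounts), compound 1 gives 267 nM
- compound 2, `COC(=O)/C=C/c1cccc(N(Cc2ccc(/C=C/c3ccccc3F)cc2)C(=O)C2CCCCC2)c1`: in this assay compound 2 gives 64 nM
- compound 3, `COC(=O)/C=C/c1cccc(N(Cc2ccc(-c3ccc(F)c(Cl)c3)cc2)C(=O)C2CCCCC2)c1`: in this assay compound 3 gives 66 nM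

Compound 1 holds the highest number of the three; compounds 2 and 3 both sit beyond the scatter below it, and neither pair with compound 1 is a single-point change.

Compound 4, `COC(=O)/C=C/c1cccc(N(Cc2ccc(-c3ccc(N(C)C)cc3)cc2)C(=O)C(C)C)c1`, differs from compound 1 in one place: 4-(dimethylamino)phenyl in place of 2-(3-(trifluoromethyl)phenyl)ethenyl on an aromatic carbon. Going by the values given here, the only measured step of similar kind, a 1.0-fold higher number from compound 2 to compound 3 (0.01 log units; within the scatter), exchanged 2-(2-fluorophenyl)ethenyl for 3-chloro-4-fluorophenyl and left the number unchanged. That bears on the loss of the ethenyl link in compound 4, but nothing measured tests the entering 4-(dimethylamino)phenyl or the leaving trifluoromethyl. The expected step of a 1.1-fold higher number from compound 1 to compound 4 (0.05 log units; within the scatter) in this assay is therefore small, with no direction beyond the scatter, and uncertain. Compound 4 is expected to give 300 nM (range 100 nM to 900 nM).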

Compound 4, half-maximal effective concentration: 57 nM
Beside the measured number, compound 4's estimate is 5.3-fold (0.72 log units) above it; measured number outside the range, below it.
By their numbers in this assay, from the lowest: compounds 4, 2 and 3 (each within the scatter of the next); then compound 1.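

In this assay, the change on this aromatic carbon, para to a large group, gives a 4.7-fold lower number from compound 1 to compound 4 (0.67 log units; beyond the scatter), so this position can respond to a swap of ethenyl-linked aryl for directly attached aryl, unlike the step of a 1.0-fold higher number from compound 2 to compound 3 (0.01 log units; within the scatter). Compound 4 also shows that a low number here does not require the ethenyl link or a halogen on the terminal ring. Nothing available explains the step.

The compounds shown leave open whether the step follows from the entering dimethylamino group, the leaving trifluoromethyl or the lost ethenyl link. From the compounds shown here alone, how a morpholine in the dimethylamino group's place would read also stays open.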